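The compounds below may be only part of what the source reports. "The series", "measured", "known", "first", "only" and "open" are said of these compounds alone.

Of the compounds shown here, two that share one core have so far been measured in a functional assay on UACC-257 cells (Homo sapiens) for inhibition, read by sulforhodamine B assay, with a stated time of 48 h, tested at 1 uM; on this read-out higher numbers stand for a weaker effect at the one concentration tested and lower numbers for a stronger effect. Compound 1 `COc1cc(Cl)cc(-c2nn(-c3cccc(NC(=O)Nc4cc(C(F)(F)F)cc(C(F)(F)F)c4)c3)cc2-c2ccncc2)c1` gives 23% in this assay. Compound 2 `COc1cc(Cl)cc(-c2nn(-c3cccc(NC(=O)Nc4ccc(Cl)c(Cl)c4)c3)cc2-c2ccncc2)c1` gives 80% in this assay, which places it highest of the two numbers, with compound 1 the nearest and sitting well beyond the scatter below it. Compound 3 `COc1cc(Cl)cc(-c2nn(-c3cccc(NC(=O)Nc4cccc(C(F)(F)F)c4)c3)cc2-c2ccncc2)c1` has not yet been measured. It differs from compound 2 in a single place: 3-(trifluoromethyl)phenyl in place of 3,4-dichlorophenyl on an amide-type nitrogen. Among the compounds with values here, no pair of measured compounds differing in one place is available, so the size of this kind of change is not fixed by any earlier step. What can be said is that compound 1, which also carries trifluoromethyl, gives a much lower number than compound 2, and compound 3 carries the same group. On that basis the step from compound 2 to compound 3 in this assay is expected to be downward and to exceed the scatter, giving a number 25 percentage points lower from compound 2 to compound 3 (beyond the scatter). Compound 3 is therefore expected to give 55% in this assay, within an estimated range from 30% to 85%.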

Compound 3, a percentage reported as activity, at one concentration (the size of the read-out at that concentration, not a potency): 78%
The estimate for compound 3 lay 23 percentage points below the measured number; measured number inside the range.
By their numbers in this assay, from the lowest: compound 1; then compounds 3 and 2 (each within the scatter of the next).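

In this assay, 3-(trifluoromethyl)phenyl in place of 3,4-dichlorophenyl on the amide-type nitrogen gives a number 2 percentage points lower from compound 2 to compound 3 (within the scatter) and so leaves the read-out within the scatter, which shows that carrying one trifluoromethyl group at this place does not by itself bring the stronger effect. Hydrogen in place of trifluoromethyl on an aromatic carbon gives a number 55 percentage points higher from compound 1 to compound 3 (beyond the scatter) in this assay and thus ties the stronger effect among these compounds to the second trifluoromethyl group on that ring, a dependence that the earlier compounds, with no single-place pair among them, could not show. Nothing at hand accounts for the size of this step.

The compounds shown leave open whether a group other than trifluoromethyl on that aromatic carbon, such as a chlorine, a nitrile, a methoxy group or an amine, would give a similar number in this assay or one closer to that of the hydrogen. They also leave open whether these steps would hold at other concentrations, since a reading at one concentration fixes no potency.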